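A few compounds are considered here, and "the series" means these few. Any claim that something is new, unique, unknown or untested is made for them only; others in the source may bear on it.

Of the compounds shown here, three have so far been measured in a functional assay on MCF7 cells (Homo sapiens) for inhibition, read by fluorescence, with a stated time of 72 h; a higher number here means a weaker inhibitor, a lower number a stronger inhibitor. Compound 1, `CC(C)n1cnc2c(N)nc(N)nc21`, gives only a limit there, > 100000 nM. Compound 2, `CN(C)c1nc(N)nc2c1ncn2CCN=[N+]=[N-]`, likewise gives only a limit, > 100000 nM. Compound 3, `CC(C)n1cnc2c(NC(=N)N)nc(NCCCCCCO)nc21`, gives 5200 nM.

Among the measured compounds shown here, compound 3 therefore stands alone as the one compound with a number rather than a limit in this assay, the other two sitting at the limit of > 100000 nM in this assay, at which 2 of the 3 values shown sit. For the measured compounds named here, because no two of the measured compounds differ in a single place, no measured step is available, and the size and direction of the next one can only be expected, not read off.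

Compound 4, `CC(C)n1cnc2c(NC(=N)N)nc(N3CCC[C@H]3CO)nc21`, has not yet been measured. It differs from compound 3 in one place: 2-(hydroxymethyl)pyrrolidin-1-yl in place of (6-hydroxyhexyl)amino on an aromatic carbon. An open chain thus gives way to a ring that carries a defined stereocentre, at the same position of the shared core.

With nothing measured to lean on, only a modest step is expected, and it is expected to run toward stronger inhibition rather than weaker; in terms of the step, the estimate means a 2.6-fold lower number from compound 3 to compound 4 (0.41 log units; beyond the scatter), a change expected to lie near the edge of the usual scatter. Compound 4 is accordingly expected to give about 2000 nM in this assay, with a likely range from 500 nM to 10000 nM.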

Compound 4, half-maximal inhibitory concentration: 6200 nM
For compound 4 the middle estimate is 3.1-fold (0.49 log units) below the measured one, and the stated range covers the measured number.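

Replacing (6-hydroxyhexyl)amino with 2-(hydroxymethyl)pyrrolidin-1-yl on this aromatic carbon, between two ring nitrogen atoms, gives a 1.2-fold higher number from compound 3 to compound 4 (0.08 log units; within the scatter) in this assay. Among the compounds shown here, this is the first reading of a change at this position, and it shows that, for this one pair, an open chain can give way to a five-membered non-aromatic ring with a defined stereocentre without a difference that can be told from the scatter. Compound 1 and compound 2 give limits and not numbers, and neither differs in one place from compound 3 or compound 4, so no step to either can be read: the limit of > 100000 nM in this assay, at which 2 of the 4 values shown sit.

What the pair cannot tell is whether the ring, the hydroxyl or the stereocentre matters on its own, as the mirror-image form of the 2-(hydroxymethyl)pyrrolidin-1-yl group does not appear among the compounds shown. It also leaves open how this position would respond to an amine or a carboxylic acid in place of the hydroxyl, or to a shorter or longer chain.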